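This account rests on a few compounds, and the source may have more. Where it says the series, first, only, none or still open, it means among the compounds named here.

Of the compounds shown here, three built on one shared core have been tested in an ADME assay on MDBK cells (Bos taurus) for cytotoxicity; on this read-out higher numbers stand for lower toxicity in this test and lower numbers for higher toxicity in this test. Compound 1 `Fc1ccc(Cn2ccc3nc(-c4ccccc4)nc-3c2)cc1` gives in this assay only a limit, > 100000 nM. Compound 2 `Clc1ccc(Cn2ccc3nc(-c4ccccc4)nc-3c2)cc1` likewise gives only a limit, > 100000 nM. Compound 3 `N#Cc1cccc(Cn2ccc3nc(-c4ccccc4)nc-3c2)c1` again gives only a limit, > 100000 nM. Going by the values given here, the steps that bear on the change now followed, a step that the two limits leave unreadable from compound 1 to compound 3 and a step that the two limits leave unreadable from compound 2 to compound 3, are therefore of unreadable size, and compound 3 stands nowhere apart from its two neighbours. The next compound, compound 4 `c1ccc(-c2nc3ccn(Cc4ccncc4)cc-3n2)cc1`, differs from compound 3 in this way: pyridin-4-yl in place of 3-cyanophenyl on a saturated chain carbon bound to an aromatic nitrogen. Since every earlier change at this place sits at the limit of > 100000 nM in this assay, at which 3 of the 3 values shown sit, no step beyond the scatter is expected, a step that the limit leaves unreadable from compound 3 to compound 4. Compound 4 is thus estimated at 150000 nM, in the range 80000 nM to 400000 nM, most probably reported once more as a limit.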

Compound 4, half-maximal cytotoxic concentration: > 100000 nM
Compound 4 ended at the assay's limit; the forecaster's own chance of this, stated with the estimate: 85%; the middle value does not contradict the limit.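

Compound 4, like compounds 1, 2 and 3, gives only a limit in this assay, so no step among these four compounds can be read. The compounds shown leave open whether any group at this place gives a readable value: the limit of > 100000 nM in this assay, at which 4 of the 4 values shown sit.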